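Pentyl to tert-Butyl on the Shared Five-Membered Core

A few compounds are considered here, and "the series" means these few. Any claim that something is new, unique, unknown or untested is made for them only; others in the source may bear on it.

compound 1 `C#CC(=O)N1C(c2cccc(F)c2)SC[C@@H]1C(=O)OCC`: 1400 nM
compound 2 `C#CC(=O)N1C(c2ccccc2F)SC[C@@H]1C(=O)OCC`: 1700 nM
compound 3 `C#CC(=O)N1C(CCCCC)SC[C@@H]1C(=O)OCC`: 1800 nM

In a functional assay on Huh-7 cells (Homo sapiens) for inhibition, read by sulforhodamine B assay (on this read-out higher numbers stand for weaker inhibition and lower numbers for stronger inhibition), the three measured compounds sit close together. Compound 3 differs from both others only within the scatter, as a 1.3-fold higher number from compound 1 to compound 3 (0.11 log units; within the scatter) and a 1.1-fold higher number from compound 2 to compound 3 (0.02 log units; within the scatter) show, and a 1.2-fold higher number from compound 1 to compound 2 (0.08 log units; within the scatter) is likewise small. Compound 4 `C#CC(=O)N1C(C(C)(C)C)SC[C@@H]1C(=O)OCC` carries the change (tert-butyl in place of pentyl on a saturated ring carbon). Going by the values given here, the steps that bear on this position, from the two fluorophenyl groups to pentyl, were all within the scatter, so the group on this ring carbon has so far moved the number little; no measured step involves tert-butyl itself. Compound 4 is therefore expected to show a 1.1-fold higher number from compound 3 to compound 4 (0.02 log units; within the scatter), a step not beyond the scatter. The estimate for compound 4 is 1900 nM, with a range from 900 nM to 4000 nM.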

Compound 4, half-maximal inhibitory concentration: 800 nM
Compound 4: the middle estimate sits 2.4-fold (0.38 log units) above what was measured, and the stated range ends above it.
By their numbers in this assay, from the lowest: compounds 4, 1, 2 and 3 (each within the scatter of the next, the first and the last beyond it).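

In this assay, going by these compounds alone, the group on this ring carbon now matters: tert-butyl gives a 2.3-fold lower number from compound 3 to compound 4 (0.35 log units; beyond the scatter) and a 2.1-fold lower number from compound 2 to compound 4 (0.33 log units; beyond the scatter) and so moves beyond the scatter, which no earlier step at this position did. Against 3-fluorophenyl the same group gives a 1.8-fold lower number from compound 1 to compound 4 (0.24 log units; within the scatter) and stays within the scatter, so the gain is not clear against every group. Nothing available explains this result. As far as these compounds go, whether isopropyl, cyclohexyl or a longer chain on this ring carbon would read like tert-butyl or like pentyl remains open, as does the effect of an amine there.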